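Cyclopropyl replaces 4-hydroxycyclohexyl on the way to compound 4

This account rests on a few compounds, and the source may have more. Where it says the series, first, only, none or still open, it means among the compounds named here.

In a physicochemical assay for solubility (a higher number here means a more soluble compound, a lower number a less soluble compound), compound 2 `CNC(=O)c1cc(C(=O)N[C@H]2CC[C@H](O)CC2)cc2c1OC[C@@]2(C)c1ccccc1` gives >= 161 ug/mL, which is a limit of the assay and not a number. All the values at hand are limits, so compound 2 has no exact place among them. Compound 4 `CNC(=O)c1cc(C(=O)NC2CC2)cc2c1OC[C@@]2(C)c1ccccc1` differs from compound 2 in one place, on an amide-type nitrogen: cyclopropyl in place of 4-hydroxycyclohexyl on an amide-type nitrogen.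

Two measured compounds already carry cyclopropyl on an amide-type nitrogen, though they differ from compound 4 elsewhere. Compound 1 `CNC(=O)c1cc(C(=O)NC2CC2)cc2c1OC[C@H]2c1cccc(OC)c1` gives >= 161 ug/mL, also a limit. Compound 3 `CNC(=O)c1cc(C(=O)NC2CC2)cc2c1OC[C@H]2c1cccc(F)c1` gives >= 175 ug/mL, again a limit. For the measured compounds named here, the only measured step, a step that the two limits leave unreadable from compound 1 to compound 3, concerns a different change, so it offers no size for this one.

With compound 3 at >= 175 ug/mL, a limit, no clear fall in this assay is expected, and no step beyond the scatter is predicted. The expected step is a step that the limit leaves unreadable from compound 2 to compound 4. The estimate for compound 4 is 165 ug/mL, within an expected range of 90 ug/mL to 190 ug/mL.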

Compound 4, solubility: >= 138 ug/mL
Compound 4 ended at the assay's limit; the forecaster's own chance of this, stated with the estimate: 70%; the middle value is on the limit's open side.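

In this assay, compound 4 gives >= 138 ug/mL, which is a limit of the assay and not a number. For the compounds shown here, compound 2 also stands at a limit, so no step between compound 2 and compound 4 can be read. The compounds shown leave open whether cyclopropyl in place of 4-hydroxycyclohexyl on an amide-type nitrogen changes the result in this assay at all.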